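Swapping a Small Ring for a Larger One at the Amine

This account rests on a few compounds, and the source may have more. Where it says the series, first, only, none or still open, it means among the compounds named here.

Compound 1 `CNC(=O)C1CCCC1n1cnc2c(NC3CC3)ncnc21`: < 10%
Compound 2 `CNC(=O)C1CC=CC1n1cnc2c(NC3CC3)ncnc21`: 50%
Compound 3 `CNC(=O)C1CCCC1n1cnc2c(NC3CCCC3)ncnc21`: 31%

All three were tested in an assay on cell membranes for displacement of a labelled ligand from adenosine receptor A1 (Rattus norvegicus), tested at 100 uM; a higher number here means more inhibition at the concentration tested (going by the name of the read-out), a lower number less inhibition. For compound 1 the result is a limit of the assay, not a number. Compound 2 and compound 3 each give a number, and compound 2 gives the higher one of the two, beyond the scatter.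

Compound 1 and compound 2 share the same core except in one part; how the two cores differ is not broken down here. Compound 3 is made from compound 1 by one change, (cyclopentyl in place of cyclopropyl on a nitrogen on an aromatic ring). This change gives a number at least 21 percentage points higher from compound 1 to compound 3 (beyond the scatter); the size can only be put as a floor because compound 1 sits at the limit of < 10% in this assay, at which 1 of the 3 values shown sits.

Compound 4 `CNC(=O)C1CC=CC1n1cnc2c(NC3CCCC3)ncnc21` has not yet been tested in this assay. It is made from compound 2 by cyclopentyl in place of cyclopropyl on a nitrogen on an aromatic ring, the same change as from compound 1 to compound 3, at a place described in the same words.

Since compound 2 starts from a number rather than a limit, and the earlier step was at least modest, compound 4 is expected to gain, though less room remains near the top of the scale. The estimated step is a number 18 percentage points higher from compound 2 to compound 4 (beyond the scatter). Compound 4 is estimated at 68%, with a likely range from 45% to 88%.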

Compound 4, a percentage reported as inhibition, at one concentration (the size of the read-out at that concentration, not a potency): < 10%
Compound 4: only a limit was reported; the forecaster's own chance of this, stated with the estimate: 2%; at least 58 percentage points between middle value and limit.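

Carried to the second core, cyclopentyl in place of cyclopropyl on a nitrogen on an aromatic ring gives a number at least 40 percentage points lower from compound 2 to compound 4 (beyond the scatter) in this assay. The change therefore does not carry over between these two cores: the same swap raises the read-out on one core and lowers it on the other, so its result on one core is a poor guide to its result on the other: the same change on two cores in this assay, a number at least 21 percentage points higher (beyond the scatter) from compound 1 to compound 3 and a number at least 40 percentage points lower (beyond the scatter) from compound 2 to compound 4, at least 61 percentage points apart, beyond the scatter of two such steps

Each of the two steps has one end at a limit of the assay, so only a floor is known for its size, and a pair of cores cannot show why the direction reverses or what the change would do on a third core: the limit of < 10% in this assay, at which 2 of the 4 values shown sit.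

The compounds shown leave open how cyclobutyl, a ring size lying between the two tested, or an open chain such as isopropyl would behave on the same nitrogen on either core, which could show whether the reversal appears gradually or abruptly. They also leave open what a carboxylic acid or a primary amide in place of the methylamide would do on each core.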